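From 4-fluorophenyl to 4-methylphenyl in the series

A few compounds are considered here, and "the series" means these few. Any claim that something is new, unique, unknown or untested is made for them only; others in the source may bear on it.

In a functional assay on PC-3 cells (Homo sapiens) for cytotoxicity, read by WST assay, with a stated time of 72 h (on this read-out lower numbers stand for stronger inhibition and higher numbers for weaker inhibition), compound 1 `O=C1Nc2c(ccc(F)c2F)C1(c1ccccc1)c1ccc(O)cc1` gives 8.9 nM and compound 2 `O=C1Nc2c(ccc(F)c2F)C1(c1ccc(O)cc1)c1ccc(F)cc1` gives 8.6 nM. Among the compounds with values here, the two values lie within the scatter of each other, so compound 2 stands level with compound 1, the only other measured compound, and no order can be drawn between them.

Compound 3 `Cc1ccc(C2(c3ccc(O)cc3)C(=O)Nc3c2ccc(F)c3F)cc1` departs from compound 2 at one place: methyl in place of fluoro on an aromatic carbon. This is methyl in place of fluoro on an aromatic carbon, para to a large group, or 4-fluorophenyl to 4-methylphenyl.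

Within the data shown here, no measured step covers this exchange directly, and methyl has not yet been measured at this carbon. Among the measured compounds shown here, the only measured step bearing on it is fluoro in place of hydrogen at the same carbon. Because a 1.0-fold lower number from compound 1 to compound 2 (0.01 log units; within the scatter) stays within the scatter, no change beyond the scatter is expected in this assay, in either direction. One step is thin evidence, so the range is kept wide.

The expected step is a 1.2-fold higher number from compound 2 to compound 3 (0.07 log units; within the scatter). For compound 3 the estimated value is 10 nM, with an expected range of 4 nM to 25 nM.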

Compound 3, half-maximal inhibitory concentration: 0.8 nM
Compound 3: the middle estimate sits 13-fold (1.10 log units) above what was measured, outside the stated range (below it).
By their numbers in this assay, from the lowest: compound 3; then compounds 2 and 1 (each within the scatter of the next).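

In this assay the carbon bearing fluoro in compound 2 turns out not to be silent: methyl in place of fluoro gives an 11-fold lower number from compound 2 to compound 3 (1.03 log units; beyond the scatter) on this carbon, and methyl in place of hydrogen gives an 11-fold lower number from compound 1 to compound 3 (1.05 log units; beyond the scatter) at the same place. Compounds 1 and 2 alone, joined by a 1.0-fold lower number from compound 1 to compound 2 (0.01 log units; within the scatter) in this read-out, gave no sign of this, so the position answers to which group it carries, with hydrogen and fluoro level with each other and methyl set apart from both, making compound 3 the strongest of the three. Nothing at hand bears on why methyl behaves so differently from the other two groups on this carbon.

The compounds shown leave open whether the drop belongs to methyl alone or carries over to a longer chain such as ethyl, to methoxy or to chloro on the same carbon. They also leave open whether an amine or a carboxylic acid at this place would keep the number as low as in compound 3, or would return it to the level of compounds 1 and 2.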